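The compounds below may be only part of what the source reports. "The series", "measured", "known", "first", "only" and "open" are said of these compounds alone.

In a functional assay on A549 cells (Homo sapiens) for antiproliferative activity, read by MTT assay, with a stated time of 48 h (a higher number here means a weaker inhibitor, a lower number a stronger inhibitor), compound 1 `CCOc1cc(-c2ccc3[nH]ccc3c2)cn2c(-c3cc(OC)c(OC)c(OC)c3)nnc12` gives 589 nM and compound 2 `CCOc1cc(-c2ccc3ccn(C)c3c2)cn2c(-c3cc(OC)c(OC)c(OC)c3)nnc12` gives 349 nM. Among the measured compounds shown here, these two numbers lie within the scatter of each other, so compound 2 cannot be separated from the only other measured compound, and its standing rests on this single comparison.

The next structure, compound 3 `CCOc1cc(-c2ccc3c(ccn3C)c2)cn2c(-c3cc(OC)c(OC)c(OC)c3)nnc12`, has the same atoms as compound 2, joined differently: 1-methyl-1H-indol-5-yl in place of 1-methyl-1H-indol-6-yl on an aromatic carbon. The group sits on an aromatic carbon of a six-membered aromatic ring with 1 nitrogen, and only its point of attachment changes. Compound 3 thus keeps the methyl group of compound 2 and shares the attachment of compound 1.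

For the measured compounds named here, only one measured step bears on this change, a 1.7-fold lower number from compound 1 to compound 2 (0.23 log units; within the scatter). It alters the methyl group and the attachment together, so the data do not isolate the effect of the attachment alone. Going by the values given here, with that small step as the only guide, no change beyond the scatter is expected in this assay.

The expected change is a 1.1-fold higher number from compound 2 to compound 3 (0.06 log units; within the scatter), which is an estimate. For compound 3 the estimated value is 400 nM, with an expected range from 130 nM to 1200 nM.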

Compound 3, half-maximal inhibitory concentration: 334 nM
Compound 3: middle estimate off by 1.2-fold (0.08 log units), on the high side; the range from low to high includes it.
By their numbers in this assay, from the lowest: compounds 3, 2 and 1 (each within the scatter of the next).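

With compound 3, the two changes that compound 2 carried together can be read apart in this assay: 1-methyl-1H-indol-5-yl in place of 1-methyl-1H-indol-6-yl, with the methyl group kept, gives a 1.0-fold lower number from compound 2 to compound 3 (0.02 log units; within the scatter), and methyl in place of hydrogen on the aromatic nitrogen, with the attachment kept, gives a 1.8-fold lower number from compound 1 to compound 3 (0.25 log units; within the scatter). Neither the point of attachment alone nor the methyl group alone moves the number beyond the scatter, so the three compounds cannot be told apart at this place on the shared core. Nothing available accounts for this lack of separation.

What the compounds shown leave open is whether anything at this place can move the number beyond the scatter, for instance an ethyl or longer chain on the indole nitrogen, or an amine or a carboxylic acid on the indole ring. Going by these compounds, it also remains open whether the same flat reading would hold with a group other than the ethoxy group on the shared core.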